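A few compounds are considered here, and "the series" means these few. Any claim that something is new, unique, unknown or untested is made for them only; others in the source may bear on it.

Within a functional assay on RKE cells for antagonist activity at Vasoactive intestinal polypeptide receptor 1 (Rattus norvegicus), read by HTRF and cAMP accumulation, with stated times of 10 min and 30 min (on this read-out lower numbers stand for stronger inhibition and higher numbers for weaker inhibition), compound 3 `N#Cc1c(NC(=O)C2CCC2)sc2c1CCCC2` gives 1800 nM, the lowest of the three numbers measured so far. Compound 1 `CCC(=O)Nc1sc2c(c1C#N)CCCC2` gives 12000 nM, and compound 2 `CC(=O)Nc1sc2c(c1C#N)CCCC2` gives 13000 nM; between these two the step of a 1.1-fold higher number from compound 1 to compound 2 (0.03 log units; within the scatter) lies within the scatter. The steps of a 6.7-fold lower number from compound 1 to compound 3 (0.82 log units; beyond the scatter) and a 7.2-fold lower number from compound 2 to compound 3 (0.86 log units; beyond the scatter) show that exchanging a short chain for a four-membered ring on the carbonyl carbon brought a modest gain. Compound 4 `N#Cc1c(NC(=O)c2ccccc2)sc2c1CCCC2` changes this same place once more: phenyl in place of cyclobutyl on a carbonyl carbon. Going by the values given here, no measured step tests an aromatic ring here, so the direction is uncertain; the ring-for-chain steps offer only a weak hint of a further small gain. For compound 4 the expected value is 1200 nM, within 250 nM to 6000 nM, an expected step of a 1.5-fold lower number from compound 3 to compound 4 (0.18 log units; within the scatter).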

Compound 4, half-maximal inhibitory concentration: 15000 nM
Estimate against measurement, compound 4: 13-fold (1.10 log units) below, and the stated range ends below it.
By their numbers in this assay, from the lowest: compound 3; then compounds 1, 2 and 4 (each within the scatter of the next).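

With an 8.3-fold higher number from compound 3 to compound 4 (0.92 log units; beyond the scatter) as phenyl replaces cyclobutyl on the carbonyl carbon, the earlier gain is lost, so having a ring at this place is not enough on its own. Phenyl also sits level with the short chains, as a 1.2-fold higher number from compound 2 to compound 4 (0.06 log units; within the scatter) and a 1.3-fold higher number from compound 1 to compound 4 (0.10 log units; within the scatter) show, leaving cyclobutyl as the only group here that stands apart. Nothing measured here explains why these two rings differ. Still open, on these data alone, is whether cyclopentyl or cyclohexyl would keep the gain of cyclobutyl. Also open, as far as these compounds go, is how a phenyl carrying an amine would behave.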